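Aryl exchange on the amide carbonyl: tolerance notes

This account rests on a few compounds, and the source may have more. Where it says the series, first, only, none or still open, it means among the compounds named here.

Measured so far:
- compound 1 `COc1ccc(-c2cnc(NC(=O)c3ccccc3O)n2C)cc1`: in a toxicity assay on THP-1 cells (Homo sapiens) for inhibition (a higher number here means that more compound is tolerated, a lower number that less compound is tolerated), compound 1 gives > 100000 nM, a limit of the assay rather than a number.
- compound 2 `CCCn1c(-c2ccc(OC)cc2)cnc1NC(=O)c1ccc(F)cc1`: in this assay compound 2 gives > 100000 nM, again a limit of the assay and not a number.

Going by the values given here, compound 1 therefore stands at the limit, with nothing to rank it against: the only other value shown is a limit as well, so both points sit at the limit of > 100000 nM in this assay, at which 2 of the 2 values shown sit. Among the compounds with values here, no step between two measured compounds is available, and no value is a number.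

Compound 3 `COc1ccc(-c2cnc(NC(=O)c3cccc(F)c3)n2C)cc1` differs from compound 1 by 3-fluorophenyl in place of 2-hydroxyphenyl on a carbonyl carbon. The change removes the hydrogen-bond donor and acceptor of the leaving group and brings in a group with neither, on the same carbonyl carbon bound to the amide-type nitrogen.

With both measured points at the limit, no step beyond the scatter is expected in either direction; the step from compound 1 to compound 3 is estimated as a number no higher from compound 1 to compound 3 (the limit leaves the size open). Compound 3 is expected to give 100000 nM in this assay, within 40000 nM to 250000 nM, most likely reported once more as a limit.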

Compound 3, half-maximal cytotoxic concentration: > 100000 nM
Compound 3: only a limit was reported (the forecaster's own chance of this, stated with the estimate: 80%); the middle value sits exactly at the limit.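

In this assay compound 3 gives > 100000 nM, a limit of the assay and not a number. The change from compound 1 to compound 3 therefore yields no readable step: the limit of > 100000 nM in this assay, at which 3 of the 3 values shown sit.

The compounds shown leave open how much of any of them is tolerated in this assay, and whether 3-fluorophenyl and 2-hydroxyphenyl differ at all.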